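Removing the fluoro from compound 2

The source may hold more compounds than are shown below. What is called first, only, known or untested is meant among the compounds shown, and "the series" means these compounds.

Measured compounds in a functional assay on HeLa cells (Homo sapiens) for inhibition, read by CCK-8 assay, with a stated time of 48 h; a lower number here means a stronger inhibitor, a higher number a weaker inhibitor:
compound 1 `COc1cc(-c2ccnc3cc(-c4ccc5cc[nH]c5c4)nn23)cc(OC)c1OC`, 125 nM
compound 2 `COc1ccc(-c2cc3nccc(-c4cc(OC)c(OC)c(OC)c4)n3n2)cc1F`, 236 nM
compound 3 `Cc1ccc(-c2cc3nccc(-c4ccc(F)cc4)n3n2)cc1`, which in this assay gives only the limit > 10000 nM and no number

Compound 2 holds the higher of the two numbers, but its nearest neighbour is compound 1, and the step of a 1.9-fold higher number from compound 1 to compound 2 (0.28 log units; within the scatter) lies within the scatter, so the two cannot be ordered. Compound 3 sits at the limit (the limit of > 10000 nM in this assay, at which 1 of the 3 values shown sits), and it differs from compound 2 in more than one place, so nothing can be read from it for the present change.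

Compound 4 `COc1ccc(-c2cc3nccc(-c4cc(OC)c(OC)c(OC)c4)n3n2)cc1` is compound 2 with one change: hydrogen in place of fluoro on an aromatic carbon. Among the measured compounds shown here, no measured step removes a fluoro; the only measured step, the swap from compound 1 to compound 2, exchanges a whole aryl group and stays within the scatter. Without a bearing step, no movement beyond the scatter is expected. The step from compound 2 to compound 4 is therefore estimated at a 1.1-fold higher number from compound 2 to compound 4 (0.03 log units; within the scatter). Compound 4 is expected near 250 nM, with a range from 100 nM to 650 nM.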

Compound 4, half-maximal inhibitory concentration: 373 nM
Beside the measured number, compound 4's estimate is 1.5-fold (0.17 log units) below it; low and high end bracket the measured number.
By their numbers in this assay, from the lowest: compounds 1, 2 and 4 (each within the scatter of the next, the first and the last beyond it). At a limit, above all of these: compound 3.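

In this assay, among the compounds shown here, the step of a 1.6-fold higher number from compound 2 to compound 4 (0.20 log units; within the scatter) is the first to isolate the fluoro alone, and on the six-membered aromatic ring, ortho to a methoxy group, hydrogen and fluoro cannot be told apart. For the compounds shown here, exchanging 1H-indol-6-yl for 4-methoxyphenyl gives a 3.0-fold higher number from compound 1 to compound 4 (0.47 log units; beyond the scatter) and is the first step beyond the scatter, though a modest one, while the 3-fluoro-4-methoxyphenyl group of compound 2 is not separated from compound 1 in this way. Nothing measured here accounts for either step.

Going by these compounds, whether a chloro, a hydroxyl or an amine at this place would separate from fluoro and hydrogen remains open. Compound 3 gives only a limit of the assay, > 10000 nM and its steps cannot be read.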